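A few compounds are considered here, and "the series" means these few. Any claim that something is new, unique, unknown or untested is made for them only; others in the source may bear on it.

Compound 1 `CNc1nc(=O)ccn1[C@@H]1O[C@H](COP(=O)(O)O)[C@@H](O)[C@H]1O`: in an in vitro functional assay on 1321-N1 cells for agonist activity at P2Y purinoceptor 4 (Homo sapiens), read by scintillation proximity assay and inositol phosphate accumulation (a lower number here means that less compound is needed, a higher number that more compound is needed for the effect), compound 1 gives > 100000 nM, which is a limit of the assay and not a number.
Compound 2 `CCCSc1nc(=O)ccn1[C@@H]1O[C@H](COP(=O)(O)OP(=O)(O)O)[C@@H](O)[C@H]1O`: in this assay compound 2 gives 4900 nM.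
Compound 3 `O=c1ccn([C@@H]2O[C@H](COP(=O)(O)OP(=O)(O)O)[C@@H](O)[C@H]2O)c(SCc2ccccc2)n1`: in this assay compound 3 gives 5980 nM.

Compound 1 thus sits at the edge of what the assay reports, as shown by the limit of > 100000 nM in this assay, at which 1 of the 3 values shown sits. Compound 4 `COc1nc(=O)ccn1[C@@H]1O[C@H](COP(=O)(O)O)[C@@H](O)[C@H]1O` differs from compound 1 by methoxy in place of methylamino on an aromatic carbon. Going by the values given here, the only single-point step measured, a 1.2-fold higher number from compound 2 to compound 3 (0.09 log units; within the scatter), concerns the chain on the sulfur of the diphosphate compounds and does not touch this change, so it offers little guidance. With compound 1 at a limit, no step beyond the scatter can be foreseen, and compound 4 is expected to give 100000 nM, between 30000 nM and 300000 nM. The expected step is a number no higher from compound 1 to compound 4 (the limit leaves the size open), most likely reported again only as a limit.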

Compound 4, half-maximal effective concentration: > 100000 nM
Compound 4 was reported as a limit; the forecaster's own chance of this, stated with the estimate: 85%; the middle value sits exactly at the limit.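

In this assay compound 4 gives > 100000 nM, a limit of the assay and not a number. Compound 1 also stands at a limit, and no step can be read between compound 1 and compound 4. The compounds shown leave open whether methoxy in place of methylamino changes the number at all.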